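Benzyl for cyclopentyl on the ring nitrogen of compound 1

This account rests on a few compounds, and the source may have more. Where it says the series, first, only, none or still open, it means among the compounds named here.

The measured compounds and their values in a physicochemical assay for solubility, read by HPLC, in phosphate buffer, measured as thermodynamic solubility, with a stated time of 24 h, at pH 6.8; a higher number here means a more soluble compound, a lower number a less soluble compound:
compound 1, `C=CC(=O)N1CC[C@H](N2C(=O)N(C3CCCC3)Cc3cnc(Nc4ccc(N5CCN(C)CC5)cc4OC)nc32)C1`: 250 ug/mL
compound 2, `C=CC(=O)NC1CCC(N2C(=O)N(Cc3ccccc3)Cc3cnc(Nc4ccc(N5CCN(C)CC5)cc4OC)nc32)CC1`: 18.8 ug/mL
compound 3, `C=CC(=O)N1CC[C@H](N2C(=O)N(c3ccccc3)Cc3cnc(Nc4ccc(N5CCN(C)CC5)c(C)c4)nc32)C1`: 1270 ug/mL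

Compound 1 holds the second highest of the three numbers in this assay. Compound 3 stands nearest, with a higher number that lies beyond the scatter, while compound 2 is furthest, with a lower number that also lies beyond the scatter. No pair among these three differs in only one place, so none of the gaps can be read as a single structural step.

Compound 4, `C=CC(=O)N1CC[C@H](N2C(=O)N(Cc3ccccc3)Cc3cnc(Nc4ccc(N5CCN(C)CC5)cc4OC)nc32)C1`, has not been measured in this assay. Its difference from compound 1 is benzyl in place of cyclopentyl on an amide-type nitrogen in a ring. Compound 2 also carries benzyl on that ring nitrogen and gives the lowest number of the three, yet it differs from compound 1 in more than one place, so it offers only a hint. The step from compound 1 to compound 4 is expected to run downward, of moderate size, as a 2.5-fold lower number from compound 1 to compound 4 (0.40 log units; beyond the scatter). Compound 4 is therefore estimated at 100 ug/mL, within a range from 30 ug/mL to 350 ug/mL.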

Compound 4, solubility: 107 ug/mL
Estimate against measurement, compound 4: 1.1-fold (0.03 log units) below; the measured number falls inside the stated range.
By their numbers in this assay, from the lowest: compound 2; then compound 4; then compound 1; then compound 3.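

In this assay, among the compounds shown here, benzyl in place of cyclopentyl on the amide-type nitrogen in a ring gives a 2.3-fold lower number from compound 1 to compound 4 (0.37 log units; beyond the scatter), the first reading of this position with the rest of the molecule held constant. With benzyl kept on that nitrogen, 1-(vinylcarbonyl)pyrrolidin-3-yl in place of 4-((vinylcarbonyl)amino)cyclohexyl gives a 5.7-fold higher number from compound 2 to compound 4 (0.76 log units; beyond the scatter), so benzyl there does not by itself bring a compound down to the level of compound 2, and the group on the neighbouring position of the comparison matters as well. Nothing at hand explains either step.

Going by these compounds, whether the benzyl step keeps its direction and size with the 4-((vinylcarbonyl)amino)cyclohexyl group in place remains open, as does the reading of the phenyl in compound 3, which differs from the others in more than one place. On these data alone, how a chain ending in an amine, such as 2-(dimethylamino)ethyl, or a carboxylic acid would behave on that ring nitrogen is also open.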